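Removing the benzyloxy group from a cytotoxicity-silent series

The compounds below may be only part of what the source reports. "The series", "measured", "known", "first", "only" and "open" are said of these compounds alone.

Measured in a functional assay on B16-F1 cells (Mus musculus) for cytotoxicity, read by sulforhodamine B assay, with a stated time of 48 h; on this read-out lower numbers stand for stronger inhibition and higher numbers for weaker inhibition:
- compound 1 `O=[N+]([O-])c1ccc(-c2nccn2S(=O)(=O)c2ccccc2)cc1`: > 10000 nM
- compound 2 `O=S(=O)(c1ccccc1)n1ccnc1-c1ccc(OCc2ccccc2)cc1`: > 10000 nM
- compound 3 `COc1cc(C(=O)n2ccnc2-c2ccccc2)cc(OC)c1OC`: > 10000 nM

In this assay, among the compounds with values here, no compound in this small set has yet given a number, and the evidence so far is the limit of > 10000 nM in this assay, at which 3 of the 3 values shown sit. Compound 2 therefore has no exact position on the scale, and its entry is only a limit.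

The next compound to be tested is compound 4 `O=S(=O)(c1ccccc1)n1ccnc1-c1ccccc1`. It follows from compound 2 by a single change, hydrogen in place of benzyloxy on an aromatic carbon. Within the data shown here, only one measured step concerns a change of this kind, a step that the two limits leave unreadable from compound 1 to compound 2, with benzyloxy in place of nitro on an aromatic carbon. That step has no readable size, so it offers neither a size nor a direction to carry over. Among the measured compounds shown here, nothing measured so far points to a gain or a loss in this assay, and no step beyond the usual scatter is expected. The expected step is a number no higher from compound 2 to compound 4 (the limit leaves the size open). A further report of only a limit is the likeliest outcome. For compound 4 the estimate is 10000 nM, with an expected range from 4000 nM to 20000 nM.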

Compound 4, half-maximal inhibitory concentration: > 10000 nM
Compound 4 was reported as a limit (the forecaster's own chance of this, stated with the estimate: 80%); the middle value lies on the limit itself.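

In this assay compound 4 gives > 10000 nM, a limit and not a number. The steps linking compound 4 with compound 1 and compound 2 therefore cannot be read, since all three compounds are reported only as limits. The compounds shown leave open whether exchanging nitro, benzyloxy or hydrogen changes cytotoxicity at all, with the only evidence being this: the limit of > 10000 nM in this assay, at which 4 of the 4 values shown sit.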